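A few compounds are considered here, and "the series" means these few. Any claim that something is new, unique, unknown or untested is made for them only; others in the source may bear on it.

Series notes, step from compound 1 to compound 3.

Compound 1 is `CC(/C=N/Nc1ccc([N+](=O)[O-])cc1)=N\NC(=O)c1ccc(C(C)(C)C)cc1`. In a functional assay on cells (Splenocyte, Mus musculus, strain BALB/c) for inhibition, read by scintillation counting and thymidine incorporation, with a stated time of 72 h (on this read-out higher numbers stand for weaker inhibition and lower numbers for stronger inhibition), compound 1 gives > 12000 nM, which is a limit of the assay and not a number. Among the measured compounds shown here, compound 2, `CC(/C=N/N(C)c1ccc([N+](=O)[O-])cc1)=N\NC(=O)c1ccc(N)cc1`, is the only other member measured so far. In this assay compound 2 gives > 12000 nM, again a limit rather than a number. Compound 1 therefore stands nowhere in particular on the numbers shown: both values sit at the same limit, as the evidence records, (the limit of > 12000 nM in this assay, at which 2 of the 2 values shown sit), and no ranking between compound 1 and compound 2 can be drawn from them.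

Compound 3 is `CC(/C=N/Nc1ccc([N+](=O)[O-])cc1)=N\NC(=O)c1ccc(N(C)C)cc1`. It differs from compound 1 by dimethylamino in place of tert-butyl on an aromatic carbon. For the measured compounds named here, no measured step between two compounds of this set is available, so the size of the change from compound 1 to compound 3 in this assay cannot be read from the data. The expectation is that no step beyond the usual scatter will appear, and that compound 3 will most probably also return a limit; the step implied by the estimate is a step that the limit leaves unreadable from compound 1 to compound 3. Compound 3 is estimated at 20000 nM in this assay, within a range from 6000 nM to 60000 nM.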

Compound 3, half-maximal inhibitory concentration: > 12000 nM
Compound 3 ended at the assay's limit (the forecaster's own chance of this, stated with the estimate: 80%); the middle value lies beyond the limit too.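

Compound 3 also returns a limit in this assay, so no step can be read for dimethylamino in place of tert-butyl on an aromatic carbon between compound 1 and compound 3: the limit of > 12000 nM in this assay, at which 3 of the 3 values shown sit.

The compounds shown leave open how strongly compound 1, compound 2 and compound 3 inhibit in this assay, and which change to the shared core, if any, would give a value inside the assay's range.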